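A few compounds are considered here, and "the series" means these few. Any claim that something is new, unique, unknown or untested is made for them only; others in the source may bear on it.

Of the compounds shown here, two sharing one core have been measured in a functional assay on aorta (Rattus norvegicus, strain Wistar) for inhibition, with a stated time of 60 min; a higher number here means a larger maximal response, a lower number a smaller maximal response. Compound 1, `COc1ccc(-c2nc3cc([N+](=O)[O-])ccc3[nH]2)c(OC)c1OC`, gives 90% in this test. Compound 2, `COc1cc(-c2nc3cc([N+](=O)[O-])ccc3[nH]2)ccc1O`, gives 91.7%; this is the higher of the two numbers, but the gap to compound 1 lies within the usual scatter, so the two results are best read as alike. Compound 3, `COc1ccc(-c2nc3cc([N+](=O)[O-])ccc3[nH]2)cc1OC`, has not yet been measured. It differs from compound 2 in one place: methyl in place of hydrogen on an oxygen on an aromatic ring. Going by the values given here, both measured compounds reach close to the full response, and the single change here is a small one, so no shift beyond the scatter is anticipated. The expected step is therefore a number 1.7 percentage points lower from compound 2 to compound 3 (within the scatter), which amounts to none beyond the scatter. For compound 3 the largest response is estimated at 90%, with a likely range from 80% to 98%.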

Compound 3, largest response reached (Emax), in percent of the reference or control that the assay uses: 75%
The estimate for compound 3 lay 15 percentage points above the measured number, outside the stated range (below it).
By their numbers in this assay, from the lowest: compound 3; then compounds 1 and 2 (each within the scatter of the next).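

Methyl in place of hydrogen on this oxygen is not a silent change: turning hydroxy into methoxy gives, in this assay, a number 16.7 percentage points lower from compound 2 to compound 3 (beyond the scatter), even though only one carbon is added. Hydrogen in place of methoxy on an aromatic carbon gives a number 15 percentage points lower from compound 1 to compound 3 (beyond the scatter), so a change in this second place lowers the number by a similar amount, and the high response does not survive every small edit to this ring. No measurement available here explains either drop.

As far as these compounds go, it remains open whether the hydroxy itself is needed or whether other groups in its place would also keep the response high. An amine or a longer ethoxy chain on that aromatic carbon would help to tell these readings apart.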